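A few compounds are considered here, and "the series" means these few. Any claim that something is new, unique, unknown or untested is made for them only; others in the source may bear on it.

Compound 1, `CCN(CCNC(=O)c1cc(Cl)c(N)cc1OC)Cc1ccccc1OC`: in a functional assay on the whole organism with Rattus norvegicus as the target (a higher number here means that more compound is needed for the effect, a lower number that less compound is needed), compound 1 gives 10 mg/kg.
Compound 2, `CCN(CCNC(=O)c1cc(Cl)c(N)cc1OC)Cc1ccccc1Cl`: compound 2 gives 10 mg/kg.
Compound 3, `COc1ccc(Cl)cc1C(=O)NCCN(C)Cc1ccccc1`: compound 3 gives 3 mg/kg.

Compound 2 and compound 1 differ in one place, (methoxy in place of chloro on an aromatic carbon); this change gives no change at the digits printed from compound 2 to compound 1 (within the scatter). Compound 3 stands apart from both: the difference between its core and that of compound 2 is not broken down here. Its value lies beyond the scatter from those of compound 1 and of compound 2.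

Compound 4, `COc1ccc(OC)c(C(=O)NCCN(C)Cc2ccccc2)c1`, is not yet measured. It differs from compound 3 by methoxy in place of chloro on an aromatic carbon. This is the same kind of change as from compound 2 to compound 1, not the same: there the entering methoxy stood ortho to a large group, here it stands meta to a large group and para to a methoxy group. Because the earlier change gave no change at the digits printed from compound 2 to compound 1 (within the scatter), a similar small step is expected, a 1.3-fold higher number from compound 3 to compound 4 (0.12 log units; within the scatter), with extra uncertainty from the different surroundings. Compound 4 is therefore estimated at 4 mg/kg, between 1.5 mg/kg and 12 mg/kg.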

Compound 4, dose for half-maximal effect: 3 mg/kg
Estimate against measurement, compound 4: 1.3-fold (0.12 log units) above; measured number inside the range.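

In this assay, methoxy in place of chloro on an aromatic carbon has now been read on two cores, and on the core of compound 3 it gives no change at the digits printed from compound 3 to compound 4 (within the scatter). The two readings agree: the same change on two cores in this assay, no change at the digits printed (within the scatter) from compound 2 to compound 1 and no change at the digits printed (within the scatter) from compound 3 to compound 4, 1.0-fold (0.00 log units) apart, within the scatter of two such steps This shows that, within this series, the change carried from one core to the other without a step beyond the scatter, here with the entering methoxy meta to a large group and para to a methoxy group; it does not show why the number stays put, nor that the same would hold on a further core or at another place on the ring, since two pairs are all that stand behind it.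

The compounds shown leave open what a fluoro group, a nitrile or a carboxylic acid would give in place of the chloro. They also leave open whether a longer chain on the side-chain nitrogen would move the number.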